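A few compounds are considered here, and "the series" means these few. Any claim that something is new, unique, unknown or untested is made for them only; others in the source may bear on it.

Measured so far:
- Compound 1 `CC(=O)c1cc(-c2ccc(F)cc2)cc2cc(-c3ccc(F)cc3)[nH]c12`: 71.6%
- Compound 2 `CC(=O)c1cc(/C=C/c2ccccc2)cc2cc(-c3ccc(F)cc3)[nH]c12`: 60.5%

In a functional assay on HeLa cells (Homo sapiens) for cytotoxicity, read by MTT assay, with a stated time of 2 days, tested at 1 uM (on this read-out lower numbers stand for a stronger effect and higher numbers for a weaker effect at the one concentration tested), compound 2 gives 60.5%, the lower of the two numbers available; its nearest neighbour is compound 1, which gives 71.6%. Within the data shown here, the one step between them, a number 11.1 percentage points lower from compound 1 to compound 2 (beyond the scatter), came with the change of 2-phenylethenyl in place of 4-fluorophenyl on an aromatic carbon and was beyond the scatter, though modest.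

Compound 3 `CC(=O)c1cc(/C=C/c2ccc(F)cc2)cc2cc(-c3ccc(F)cc3)[nH]c12` is the next member. It differs from compound 2 by fluoro in place of hydrogen on an aromatic carbon, so the 2-phenylethenyl of compound 2 becomes 2-(4-fluorophenyl)ethenyl. Among the measured compounds shown here, no measured step bears directly on this change: the only step available, a number 11.1 percentage points lower from compound 1 to compound 2 (beyond the scatter), exchanged one whole group for another rather than adding a single fluoro to a ring that was already present, and no pair of measured compounds differs by a fluoro alone. With nothing to anchor a shift, the expectation is a step within the scatter, a number 1.5 percentage points lower from compound 2 to compound 3 (within the scatter), in no particular direction. Compound 3 is therefore estimated to give 59%, with a plausible range from 42% to 76%.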

Compound 3, a percentage reported as activity, at one concentration (the size of the read-out at that concentration, not a potency): 53.7%
For compound 3 the middle estimate is 5.3 percentage points above the measured one; the measured number falls inside the stated range.
By their numbers in this assay, from the lowest: compounds 3 and 2 (each within the scatter of the next); then compound 1.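

In this assay placing a fluoro on the ring of the 2-phenylethenyl group, para to a large group, gives a number 6.8 percentage points lower from compound 2 to compound 3 (within the scatter) and so does not separate the two compounds on the present numbers. The larger exchange on the aromatic carbon now has a second example: 2-(4-fluorophenyl)ethenyl in place of 4-fluorophenyl gives a number 17.9 percentage points lower from compound 1 to compound 3 (beyond the scatter) and, like the exchange with the plain 2-phenylethenyl group, lies beyond the scatter, so among these three compounds both groups with the ethenyl link stand apart from compound 1 whether or not their ring carries fluoro. Nothing measured here accounts for these differences.

Going by these compounds, whether a different group on that same ring, such as methoxy or an amine, would produce a step beyond the scatter remains open. So does whether a saturated ethyl link or a longer chain in place of the ethenyl link would preserve the difference from compound 1, and how any of these compounds would behave at other concentrations.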